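From vinyl to isopropoxy: a step hidden behind a limit

This account rests on a few compounds, and the source may have more. Where it says the series, first, only, none or still open, it means among the compounds named here.

Compound 1 `CCOC(=O)c1c(-c2cc(F)cc(OC)c2)[nH]c2cc(OC)ccc2c1=O`: > 21500 nM
Compound 2 `C=Cc1cccc(-c2[nH]c3cc(OC)ccc3c(=O)c2C(=O)OCC)c1`: > 21500 nM
Compound 3 `CCOC(=O)c1c(-c2cccc(OC)c2)[nH]c2cc(OC)ccc2c1=O`: > 21500 nM

All three compounds were tested in an ADME assay on HepG2 cells (Homo sapiens) for cytotoxicity, read by luminescence, with a stated time of 72 h (a lower number here means that less compound is needed, a higher number that more compound is needed for the effect), and share one core. Compound 2 reads > 21500 nM here, which is a limit of the assay and not a number. Compound 1 reads > 21500 nM here, also a limit. Compound 3 reads > 21500 nM here, again a limit. The set as a whole shows the limit of > 21500 nM in this assay, at which 3 of the 3 values shown sit, and nothing finer, so compound 2 has no exact place on the scale.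

Compound 4 `CCOC(=O)c1c(-c2cccc(OC(C)C)c2)[nH]c2cc(OC)ccc2c1=O` is not yet measured. It carries isopropoxy in place of vinyl on an aromatic carbon.

The closest measured change is methoxy in place of vinyl, the step that the two limits leave unreadable from compound 2 to compound 3 in this series. The other two are a step that the two limits leave unreadable from compound 1 to compound 2 and a step that the two limits leave unreadable from compound 1 to compound 3 here. None of the three has a readable size, so no size can be carried over to the new change. For the measured compounds named here, with no measured step to suggest otherwise, the expected step that the limit leaves unreadable from compound 2 to compound 4 is none beyond the scatter, in neither direction. For compound 4 the estimate is 30000 nM with an expected range (15000 nM to 60000 nM), and another limit is the likeliest report.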

Compound 4, half-maximal effective concentration: > 21500 nM
Compound 4 gave a limit, no number; the forecaster's own chance of this, stated with the estimate: 85%; the middle value does not contradict the limit.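

Compound 4 reads > 21500 nM, which is a limit and not a number. Its steps from compound 2 and compound 3 cannot be read, because the result offers only one shared limit: the limit of > 21500 nM in this assay, at which 4 of the 4 values shown sit.

The compounds shown leave open the exact value of each compound in this assay, and whether vinyl, methoxy and isopropoxy differ there at all.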